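Replacing the Morpholine Amide with a Hydroxyethyl Amide

A few compounds are considered here, and "the series" means these few. Any claim that something is new, unique, unknown or untested is made for them only; others in the source may bear on it.

Going by the values given here, the shared core of this series carries a propanamide arm, and the two compounds measured so far differ only in the group on the amide carbonyl carbon. Compound 1 `COc1cc2c(cc1OC)C(CC(=O)N(C)C)CC2` gives 35.9% in a functional assay on the whole organism (strain Wistar) for inhibition, with Rattus norvegicus as the target, read by paw edema, with stated times of 60 min and 4 h, at a dose of 100 mg/kg by the oral route; on this read-out lower numbers stand for less inhibition and higher numbers for more inhibition at the one dose given (going by the name of the read-out). Compound 2 `COc1cc2c(cc1OC)C(CC(=O)N1CCOCC1)CC2` gives 13.3% in the same test, the lower of the two numbers, and the drop a number 22.6 percentage points lower from compound 1 to compound 2 (beyond the scatter) shows that the group on this carbonyl carbon can shift the result well beyond the scatter.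

Compound 3 `COc1cc2c(cc1OC)C(CC(=O)NCCO)CC2` changes that same position again: (2-hydroxyethyl)amino in place of morpholin-4-yl on a carbonyl carbon. Among the compounds with values here, because the single measured step of a number 22.6 percentage points lower from compound 1 to compound 2 (beyond the scatter) moved the read-out when the amide substituent changed, a change of comparable size is plausible here; with only one such step, its direction is uncertain, though a return toward the smaller, non-ring amide of compound 1 is expected. Compound 3 is therefore estimated at 25%, within 8% to 42%, an expected step of a number 11.7 percentage points higher from compound 2 to compound 3 (beyond the scatter).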

Compound 3, a percentage reported as inhibition, in the whole organism at one dose (the size of the read-out at that dose, not a potency): 9.37%
Compound 3: middle estimate off by 15.6 percentage points, on the high side; the range from low to high includes it.
By their numbers in this assay, from the lowest: compounds 3 and 2 (each within the scatter of the next); then compound 1.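

Trading the morpholin-4-yl ring for the open (2-hydroxyethyl)amino chain, which has hydrogen-bond donors where the ring has none, gives a number 3.9 percentage points lower from compound 2 to compound 3 (within the scatter), so this test does not separate these two groups. The comparison with dimethylamino gives a number 26.5 percentage points lower from compound 1 to compound 3 (beyond the scatter), so two different replacements, one with a ring and one without, both stand apart from compound 1, and a ring on this carbonyl carbon is not needed for that gap. No supporting data bear on this result, so the reason for the gap stays unknown.

As far as these compounds go, it remains open whether a small methylamino group or a longer diethylamino group would sit with compound 1 or with compound 2 and compound 3. The compounds shown also do not tell how a carboxylic acid in place of the amide would behave.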